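This account rests on a few compounds, and the source may have more. Where it says the series, first, only, none or still open, it means among the compounds named here.

The measured compounds:
compound 1, `CC1CCN(C2CCN(S(=O)(=O)c3ccc(C#N)cc3)CC2)CC1`, giving 2800 nM in a functional assay on DLD-1 cells (Homo sapiens) for antiproliferative activity, read by CellTiter-Glo, with a stated time of 72 h; a lower number here means a stronger inhibitor, a higher number a weaker inhibitor
compound 2, `COc1ccccc1-c1ccc(S(=O)(=O)N2CCC(N3CCC(C)CC3)CC2)cc1`, giving 26 nM
compound 3, `CC1CCN(C2CCN(S(=O)(=O)c3ccc(-c4ccc(Cl)cc4)cc3)CC2)CC1`, giving 105 nM

Compound 3 stands second highest of the three numbers in this assay: the step of a 4.0-fold higher number from compound 2 to compound 3 (0.61 log units; beyond the scatter) separates it from compound 2, and the step of a 27-fold lower number from compound 1 to compound 3 (1.43 log units; beyond the scatter) from compound 1. Compound 4, `CC1CCN(C2CCN(S(=O)(=O)c3ccc(OCc4ccccc4)cc3)CC2)CC1`, has not yet been measured in this assay. It differs from compound 3 in one place: benzyloxy in place of 4-chlorophenyl on an aromatic carbon.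

Two of the measured steps bear on this position. The steps of a 110-fold lower number from compound 1 to compound 2 (2.03 log units; beyond the scatter) and a 27-fold lower number from compound 1 to compound 3 (1.43 log units; beyond the scatter) show that putting a group carrying an aromatic ring in place of the cyano lowers the number by a large amount in both cases, while the step of a 4.0-fold higher number from compound 2 to compound 3 (0.61 log units; beyond the scatter) shows that exchanging one such aromatic group for another moves the number only modestly. Benzyloxy again carries an aromatic ring at the same position, so compound 4 is expected to stay in the range of compounds 2 and 3 rather than return toward compound 1, with a step of a 1.4-fold higher number from compound 3 to compound 4 (0.15 log units; within the scatter) that is expected to be modest at most. For compound 4 the estimate in this assay is 150 nM, with a range from 40 nM to 600 nM.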

Compound 4, half-maximal inhibitory concentration: 385 nM
For compound 4 the middle estimate is 2.6-fold (0.41 log units) below the measured one, within the range that was stated.
By their numbers in this assay, from the lowest: compound 2; then compound 3; then compound 4; then compound 1.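

In this assay the benzyloxy result shows that carrying an aromatic ring at this position does not by itself fix the number: there is a 3.7-fold higher number from compound 3 to compound 4 (0.56 log units; beyond the scatter) and a 15-fold higher number from compound 2 to compound 4 (1.17 log units; beyond the scatter), so an exchange among groups that carry such a ring can reach a large size, which the step between 2-methoxyphenyl and 4-chlorophenyl did not show. The advantage over the nitrile survives but shrinks, with a 7.3-fold lower number from compound 1 to compound 4 (0.86 log units; beyond the scatter) as a modest step, whereas 2-methoxyphenyl and 4-chlorophenyl in the same place each gave a large one. Nothing measured here accounts for these differences in size.

Benzyloxy differs from 4-chlorophenyl both in the oxygen and carbon that link its ring to the core and in lacking the chlorine, so the compounds shown cannot say which of these changes goes with the higher number. A plain phenyl or a phenoxy group in this place would begin to separate the two, and an amine such as piperidine or a carboxylic acid on the outer ring would show how far this position tolerates other kinds of group.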